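The source may hold more compounds than are shown below. What is called first, only, known or untested is meant among the compounds shown, and "the series" means these compounds.

Compound 1 (`Nc1nc(N)c2cc(CSC(=S)N3CCN(c4ccccc4)CC3)ccc2n1`) gives 4120 nM
Compound 2 (`Cc1ccc(N2CCN(C(=S)SCc3ccc4nc(N)nc(N)c4c3)CC2)c(C)c1`) gives 4070 nM
Compound 3 (`Nc1nc(N)c2cc(CSC(=S)N3CCN(c4ccc(F)cc4)CC3)ccc2n1`) gives 3270 nM

All three values come from a functional assay on HCT-116 cells (Homo sapiens) for antiproliferative activity, read by MTT assay, with a stated time of 72 h (a higher number here means a weaker inhibitor, a lower number a stronger inhibitor), and sit close together. Compound 2 stands level with the other two, as its steps show (a 1.0-fold lower number from compound 1 to compound 2 (0.01 log units; within the scatter); a 1.2-fold lower number from compound 2 to compound 3 (0.10 log units; within the scatter)). Compound 4 (`Nc1nc(N)c2cc(CSC(=S)N3CCN(c4ccc(F)cc4F)CC3)ccc2n1`) differs from compound 2 in one place: 2,4-difluorophenyl in place of 2,4-dimethylphenyl on an amine nitrogen in a ring. Compound 3 offers the closest guide, both for fluoro in place of hydrogen (a 1.3-fold lower number from compound 1 to compound 3 (0.10 log units; within the scatter)) and for 4-fluorophenyl in place of 2,4-dimethylphenyl (a 1.2-fold lower number from compound 2 to compound 3 (0.10 log units; within the scatter)). These steps are small, so no change beyond the scatter is expected in this assay. The estimated step is small (a 1.2-fold lower number from compound 2 to compound 4 (0.07 log units; within the scatter)). For compound 4 the expected value is 3500 nM (estimated range 2000 nM to 6000 nM).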

Compound 4, half-maximal inhibitory concentration: 5150 nM
For compound 4 the middle estimate is 1.5-fold (0.17 log units) below the measured one, within the range that was stated.
By their numbers in this assay, from the lowest: compounds 3, 2, 1 and 4 (each within the scatter of the next).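

With 2,4-difluorophenyl on the amine nitrogen, compound 4 stays level with the 2,4-dimethylphenyl group (a 1.3-fold higher number from compound 2 to compound 4 (0.10 log units; within the scatter)) and with plain phenyl (a 1.3-fold higher number from compound 1 to compound 4 (0.10 log units; within the scatter)), and the added fluoro also stays within the scatter (a 1.6-fold higher number from compound 3 to compound 4 (0.20 log units; within the scatter)). Across these four compounds, then, methyl and fluoro groups on this aromatic ring give no step beyond the scatter. No supporting measurement is available to explain this result. From the compounds shown here alone, all four compounds keep an aromatic ring at this place, so it remains open how a carboxylic acid, an amine or a longer chain on this nitrogen would behave.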